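Aryl swap on the piperazine nitrogen of the saccharin-linked series

The source may hold more compounds than are shown below. What is called first, only, known or untested is meant among the compounds shown, and "the series" means these compounds.

Measured so far in an ADME assay on HEK293 cells for displacement of a labelled ligand from 5-hydroxytryptamine receptor 7 (Homo sapiens), read by radioligand binding, with a stated time of 1 h; a higher number here means a weaker inhibitor, a lower number a stronger inhibitor:
- compound 1 `O=C1c2ccccc2S(=O)(=O)N1CCCCCCN1CCN(c2ccccc2Cl)CC1`: 120 nM
- compound 2 `COc1cccc(N2CCN(CCCCCCN3C(=O)c4ccccc4S3(=O)=O)CC2)c1`: 305 nM

Compound 2 gives the higher of the two numbers; the step of a 2.5-fold higher number from compound 1 to compound 2 (0.41 log units; beyond the scatter) shows how much the group on the ring nitrogen matters. Compound 3 `O=C1c2ccccc2S(=O)(=O)N1CCCCCCN1CCN(c2cccc3ccccc23)CC1` carries the change (naphthalen-1-yl in place of 3-methoxyphenyl on an amine nitrogen in a ring). Among the measured compounds shown here, no measured step covers this exact exchange; only a 2.5-fold higher number from compound 1 to compound 2 (0.41 log units; beyond the scatter) bears on it, as another change of aryl at the same place, so a step of similar size is expected, leaning toward a lower number. Compound 3 is therefore expected at 120 nM (range 30 nM to 500 nM), an estimated step of a 2.5-fold lower number from compound 2 to compound 3 (0.41 log units; beyond the scatter).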

Compound 3, inhibition constant: 20 nM
Compound 3: middle estimate off by 6.0-fold (0.78 log units), on the high side, outside the stated range (below it).
By their numbers in this assay, from the lowest: compound 3; then compound 1; then compound 2.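

In this assay naphthalen-1-yl on the ring nitrogen gives a 15-fold lower number from compound 2 to compound 3 (1.18 log units; beyond the scatter) and also a 6.0-fold lower number from compound 1 to compound 3 (0.78 log units; beyond the scatter). This aryl position therefore spans a much wider range than the first pair suggested, and compound 3, with its 2 six-membered aromatic rings, has the lowest number of the three. No measurement shown accounts for this gain. Open, from the compounds shown here alone, is whether the gain depends on the point of attachment of the second ring, which a naphthalen-2-yl group would test. A quinolin-8-yl group would show whether a ring nitrogen is accepted there.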